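The compounds below may be only part of what the source reports. "The series", "measured", "known", "first", "only" and "open" are said of these compounds alone.

Working notes on the series.

Compound 1 `COc1ccc(-c2cc(/N=C3/NC(=O)CS3)cs2)cc1` carries a methoxy on the pendant aromatic ring. In a functional assay on HT-29 cells (Homo sapiens) for cytotoxicity, read by MTT assay, with a stated time of 72 h (a lower number here means a stronger inhibitor, a higher number a weaker inhibitor), compound 1 gives only the assay limit of > 50000 nM. Compound 2 `O=C1CS/C(=N\c2csc(-c3ccccc3)c2)N1` has hydrogen in place of that methoxy. In this assay compound 2 likewise gives only the limit of > 50000 nM. The step that the two limits leave unreadable from compound 1 to compound 2 is therefore not readable, both values sitting at the limit of > 50000 nM in this assay, at which 2 of the 2 values shown sit.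

Compound 3 `CC(C)(C)c1cc(/N=C2/NC(=O)CS2)cs1` is the next change: tert-butyl in place of phenyl on an aromatic carbon. For the measured compounds named here, the only measured step, from compound 1 to compound 2, gives no readable size, so no direction for the change in this assay can be drawn from it. With both measured compounds at the limit, compound 3 is expected to remain at or about the limit, an expected step that the limit leaves unreadable from compound 2 to compound 3. The estimate for compound 3 in this assay is 60000 nM, with an expected range from 20000 nM to 200000 nM.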

Compound 3, half-maximal inhibitory concentration: > 50000 nM
Compound 3 was reported as a limit (the forecaster's own chance of this, stated with the estimate: 85%); the middle value does not contradict the limit.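

Compound 2 and compound 3 both stand only at a limit in this assay, so the step between them cannot be read: the limit of > 50000 nM in this assay, at which 3 of the 3 values shown sit.

The compounds shown leave open whether any change on the shared core brings the value in this assay away from that limit.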